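A few compounds are considered here, and "the series" means these few. Any claim that something is new, unique, unknown or untested is made for them only; others in the source may bear on it.

Compound 1 `COC(=O)c1cccc(NC(=O)c2cc3cc([N+](=O)[O-])ccc3o2)c1`: 25 ug/mL
Compound 2 `CC(C)(C)OC(=O)NCc1ccccc1NC(=O)c1ccc(-c2ccccc2)cc1`: < 5 ug/mL

In a physicochemical assay for solubility (a lower number here means a less soluble compound, a higher number a more soluble compound), compound 1 gives 25 ug/mL. For compound 2 the result is only a limit of the assay, < 5 ug/mL, so its solubility is not known as a number. This is the limit of < 5 ug/mL in this assay, at which 1 of the 2 values shown sits. Compound 3 `NC(=O)c1ccccc1NC(=O)c1ccc(-c2ccccc2)cc1` has not yet been measured. It differs from compound 2 in one place: carbamoyl in place of ((tert-butoxycarbonyl)amino)methyl on an aromatic carbon. The group that leaves is larger than the one that enters, as the counts show, and each carries one hydrogen-bond donor. Within the data shown here, no measured pair of compounds traces this kind of change, so the direction rests on expectation alone. A rise in solubility is expected, with the step from compound 2 to compound 3 estimated at an at least 2.4-fold higher number from compound 2 to compound 3 (0.38 log units; beyond the scatter). For compound 3 the expected value in this assay is 12 ug/mL, within a range from 3 ug/mL to 45 ug/mL. A reading that is again only a limit remains possible.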

Compound 3, solubility: 5 ug/mL
For compound 3 the middle estimate is 2.4-fold (0.38 log units) above the measured one; low and high end bracket the measured number.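

Replacing ((tert-butoxycarbonyl)amino)methyl with carbamoyl on this aromatic carbon, ortho to a large group, gives in this assay a number no lower from compound 2 to compound 3 (the limit leaves the size open). Compound 3 gives 5 ug/mL, an actual number, so this place now has a reading against which further changes can be compared. How far the change moved solubility cannot be read, because compound 2 gives only a limit and not a number: the limit of < 5 ug/mL in this assay, at which 1 of the 3 values shown sits.

Compound 1 differs from compound 3 in more than one place, so it adds nothing about this particular change. Still open, from the compounds shown here alone, is how other groups on the same aromatic carbon would read in this assay, such as a simple aminomethyl group, which would keep the chain but lose the tert-butoxycarbonyl part, or a carboxylic acid in place of the carbamoyl.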